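A few compounds are considered here, and "the series" means these few. Any claim that something is new, unique, unknown or untested is made for them only; others in the source may bear on it.

Measured compounds in a functional assay on SV5A8 cells (Homo sapiens) for cytotoxicity; a lower number here means a stronger inhibitor, a higher number a weaker inhibitor:
compound 1 `CCCCN1CCC(C(=O)Nc2ccc(CNc3nc(N(C)C)nc4cc(C)ccc34)cc2)CC1`, > 10500 nM, a limit of the assay
compound 2 `Cc1ccc2c(NCc3ccc(NC(=O)C4CCN(Cc5ccccc5F)CC4)cc3)nc(N(C)C)nc2c1`, > 6670 nM, a limit of the assay
compound 3 `Cc1ccc2c(NCc3ccc(NC(=O)C4CCN(Cc5ccc(F)cc5Cl)CC4)cc3)nc(N(C)C)nc2c1`, > 5910 nM, a limit of the assay

Compound 3 stands only at a limit in this assay, as do the two other values, so no order among the three compounds can be read. Compound 4 `Cc1ccc2c(NCc3ccc(NC(=O)C4CCN(C)CC4)cc3)nc(N(C)C)nc2c1` carries the change (hydrogen in place of 2-chloro-4-fluorophenyl on a saturated chain carbon bound to an amine nitrogen in a ring). The steps a step that the two limits leave unreadable from compound 1 to compound 2, a step that the two limits leave unreadable from compound 1 to compound 3 and a step that the two limits leave unreadable from compound 2 to compound 3 all sit on the same saturated chain carbon bound to an amine nitrogen in a ring, yet none has a readable size because of the limit of > 10500 nM in this assay, at which 1 of the 3 values shown sits, the limit of > 5910 nM in this assay, at which 1 of the 3 values shown sits, and the limit of > 6670 nM in this assay, at which 1 of the 3 values shown sits, are each limits. Among the measured compounds shown here, no step at this position is therefore known beyond the scatter, and for compound 4 a further limit is expected rather than a readable number. Compound 4 is estimated at 12000 nM, range 3000 nM to 50000 nM. The expected step that the limit leaves unreadable from compound 3 to compound 4 is not taken as a real change.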

Compound 4, half-maximal inhibitory concentration: > 17300 nM
Compound 4 gave a limit, no number (the forecaster's own chance of this, stated with the estimate: 80%); middle value at least 1.4-fold (0.15 log units) from the limit.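

In this assay compound 4 gives > 17300 nM, a limit. Among the compounds shown here, compound 1, compound 2 and compound 3 also stand at limits, and no step to compound 4 can be read. Going by these compounds, the order of these four compounds, and whether the group at this place matters, stays open.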